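A few compounds are considered here, and "the series" means these few. Any claim that something is new, unique, unknown or untested is made for them only; others in the source may bear on it.

Working notes on the series. The shared core is that of compound 1 `CC[C@H](C)[C@H](N)CN(C(=O)[C@@H]1C[C@H]1c1ccccc1)c1ccc(-c2ccccc2)cc1`, which in a functional assay for agonist activity at G protein-coupled receptor 88 (Homo sapiens), read by HTRF and cAMP accumulation (a higher number here means that more compound is needed for the effect, a lower number that less compound is needed), gives 230 nM; 800 nM (2 entries); the spread in these repeats, (the several entries of compound 1 in this assay, 230 nM; 800 nM (2 entries)), sets the scale for reading the rest. Compound 2 `CC[C@H](C)[C@H](N)CN(C(=O)[C@@H]1C[C@H]1c1ccccc1)c1ccc(-c2ccc(C(C)(C)C)cc2)cc1`, carrying tert-butyl on the outer ring, gives 750 nM in this assay. Compound 3 `CC[C@H](C)[C@H](N)CN(C(=O)[C@@H]1C[C@H]1c1ccccc1)c1ccc(-c2ccc(OC)cc2)cc1` gives 120 nM, the lowest of the two single numbers in this assay; the step of a 6.3-fold lower number from compound 2 to compound 3 (0.80 log units; beyond the scatter) is beyond the scatter, with compound 2 as the nearest neighbour.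

Compound 4 `CC[C@H](C)[C@H](N)CN(C(=O)[C@@H]1C[C@H]1c1ccccc1)c1ccc(-c2ccc(COC(C)(C)C)cc2)cc1` differs from compound 3 in one place: (tert-butoxy)methyl in place of methoxy on an aromatic carbon. Going by the values given here, no measured step covers this exact exchange. Among the compounds with values here, the only step that bears on it is the one from compound 2 to compound 3, where the bulkier tert-butyl group gave the higher number by a 6.3-fold lower number from compound 2 to compound 3 (0.80 log units; beyond the scatter). The (tert-butoxy)methyl group is likewise larger than methoxy, so the expectation for compound 4 is a number somewhat above that of compound 3, with the step estimated as a 2.9-fold higher number from compound 3 to compound 4 (0.46 log units; beyond the scatter). For compound 4 the estimate in this assay is 350 nM, with a range from 120 nM to 1100 nM.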

Compound 4, half-maximal effective concentration: 280 nM
For compound 4 the middle estimate is 1.3-fold (0.10 log units) above the measured one; low and high end bracket the measured number.
By their numbers in this assay, from the lowest: compound 3; then compound 4; then compound 2.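

In this assay, the para position of the outer ring accepts the much larger (tert-butoxy)methyl group at a moderate cost, with a 2.3-fold higher number from compound 3 to compound 4 (0.37 log units; beyond the scatter). The same group, which ends in a tert-butyl unit reached through a methylene and an oxygen, also gives a 2.7-fold lower number from compound 2 to compound 4 (0.43 log units; beyond the scatter). Across compound 2, compound 3 and compound 4, the number therefore does not simply follow the size of the group, and compound 4 is the one that goes against a reading by bulk alone.

On these data alone, whether an amine, a carboxylic acid or a plain longer alkyl chain at this position would follow the same order remains open. How far any of these groups improves on the unsubstituted ring also stays unsettled, since compound 1 has no single number to compare against: the several entries of compound 1 in this assay, 230 nM; 800 nM (2 entries)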